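Compound 3 to compound 4: nitro in place of methoxy

The source may report more compounds than this note shows. Statements on the series, on what has been measured and on what is new or still open speak of the compounds shown alone.

In a functional assay on HT-29 cells (Homo sapiens) for antiproliferative activity, read by MTT assay, with a stated time of 72 h (a higher number here means a weaker inhibitor, a lower number a stronger inhibitor), compound 3 (`COc1cccc(-n2ccnc2-c2cc(OC)c(OC)c(OC)c2)c1`) gives 18900 nM, level within the scatter with compound 2 (`COc1cc(-c2nccn2-c2cccc(C)c2)cc(OC)c1OC`) at 14600 nM. Compound 1 (`COc1ccc(-n2ccnc2-c2cc(OC)c(OC)c(OC)c2)cc1[N+](=O)[O-]`), which carries a nitro group, gives a clearly lower 600 nM. Compound 4 (`COc1cc(-c2nccn2-c2cccc([N+](=O)[O-])c2)cc(OC)c1OC`) has nitro in place of methoxy on an aromatic carbon, meta to a large group: nitro in place of methoxy on an aromatic carbon. Going by the values given here, the one measured step at that place, a 1.3-fold higher number from compound 2 to compound 3 (0.11 log units; within the scatter), is methoxy in place of methyl and lies within the scatter. A move to a lower number in this assay is expected because compound 1 with its nitro group gives 600 nM. Compound 1 also carries a methoxy group that compound 4 lacks, so only part of that gap is expected. The expected change is a 3.8-fold lower number from compound 3 to compound 4 (0.58 log units; beyond the scatter). For compound 4 the estimate is 5000 nM, with an expected range of 900 nM to 20000 nM.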

Compound 4, half-maximal inhibitory concentration: > 100000 nM
Compound 4: no number, only a limit; the forecaster's own chance of this, stated with the estimate: 10%; at least 20-fold (1.30 log units) between middle value and limit.
By their numbers in this assay, from the lowest: compound 1; then compounds 2 and 3 (each within the scatter of the next). At a limit, above all of these: compound 4.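

In this assay compound 4 gives no number, only a limit: the limit of > 100000 nM in this assay, at which 1 of the 4 values shown sits.

Nitro at this place, meta to a large group, does not bring the low number of compound 1, and the steps run the other way: an at least 5.2-fold higher number from compound 3 to compound 4 (0.72 log units; beyond the scatter) and an at least 6.8-fold higher number from compound 2 to compound 4 (0.83 log units; beyond the scatter).

The methoxy group of compound 1 carries much of the difference, since hydrogen in its place gives an at least 160-fold higher number from compound 1 to compound 4 (2.22 log units; beyond the scatter).

On these data alone, whether that methoxy group gives a low number without the nitro group stays open. So does how an amine or a carboxylic acid in place of the nitro group would read in this assay.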